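Repeating One Substituent Swap on a Second Core

The source may hold more compounds than are shown below. What is called first, only, known or untested is meant among the compounds shown, and "the series" means these compounds.

Of the compounds shown here, three have been tested so far in a functional assay on Ehrlich cells (Mus musculus) for cytotoxicity, read by trypan blue exclusion, with a stated time of 48 h; on this read-out higher numbers stand for weaker inhibition and lower numbers for stronger inhibition. Compound 1 `Cc1ccc(-c2csc(NC(=O)COc3ccccc3C)n2)cc1` gives 54900 nM. Compound 2 `Cc1ccc(-c2csc(NC(=O)COc3ccc(F)cc3F)n2)cc1` gives 14000 nM. Compound 3 `Cc1ccccc1OCC(=O)Nc1nc(-c2ccc(Br)cc2)cs1` gives 44500 nM.

Compound 2 differs from compound 1 by 2,4-difluorophenyl in place of 2-methylphenyl on an oxygen on a saturated carbon, and this step is a 3.9-fold lower number from compound 1 to compound 2 (0.59 log units; beyond the scatter). Compound 3 differs from compound 1 in the core, by bromo in place of methyl on an aromatic carbon; that step is a 1.2-fold lower number from compound 1 to compound 3 (0.09 log units; within the scatter), so compound 1 and compound 3 cannot be told apart on this read-out.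

Compound 4 `O=C(COc1ccc(F)cc1F)Nc1nc(-c2ccc(Br)cc2)cs1` has not yet been measured. It differs from compound 3 by 2,4-difluorophenyl in place of 2-methylphenyl on an oxygen on a saturated carbon. This is the same change that separates compound 1 from compound 2, and the surroundings of the place where it is made are described in the same words for both pairs, so the two changes can be treated as the same change carried onto a second core. Among the measured compounds shown here, the two cores differ by bromo in place of methyl on an aromatic carbon, which by itself made no step that the scatter can resolve.

The change from compound 1 to compound 2 is taken as the guide, and compound 3 stands where compound 1 stands. On that basis the expected step is a 3.7-fold lower number from compound 3 to compound 4 (0.57 log units; beyond the scatter). This rests on a single measured pair, so the range is kept wide. Compound 4 is expected to give 12000 nM, estimated to fall between 5000 nM and 30000 nM.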

Compound 4, half-maximal inhibitory concentration: 44700 nM
Compound 4: the middle estimate sits 3.7-fold (0.57 log units) below what was measured, and the stated range ends below it.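

In this assay, putting 2,4-difluorophenyl in place of 2-methylphenyl on the bromo core gives a 1.0-fold higher number from compound 3 to compound 4 (0.00 log units; within the scatter) and so does not repeat the drop seen on the methyl core: the same change on two cores in this assay, a 3.9-fold lower number (0.59 log units; beyond the scatter) from compound 1 to compound 2 and a 1.0-fold higher number (0.00 log units; within the scatter) from compound 3 to compound 4, 3.9-fold (0.60 log units) apart, beyond the scatter of two such steps. Read the other way, bromo in place of methyl on an aromatic carbon gives a 3.2-fold higher number from compound 2 to compound 4 (0.50 log units; beyond the scatter) when the 2,4-difluorophenyl group is present, although the same swap produced no step the scatter can resolve when the 2-methylphenyl group was present: the same change on two cores in this assay, a 1.2-fold lower number (0.09 log units; within the scatter) from compound 1 to compound 3 and a 3.2-fold higher number (0.50 log units; beyond the scatter) from compound 2 to compound 4, 3.9-fold (0.60 log units) apart, beyond the scatter of two such steps. Among these four compounds, then, the effect of one change depends on which group stands at the other place, so a step measured on one core cannot simply be added onto the next, but the data do not show why this happens or whether it holds for any other pair of groups.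

The compounds shown leave open whether this dependence is specific to bromo, since only methyl and bromo have been compared on that aromatic carbon, and a chloro or methoxy group there could test it. They also leave open how the two cores would respond if an amine or a carboxylic acid took the place of the 2,4-difluorophenyl group.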